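The compounds below may be only part of what the source reports. "The series", "measured", "known", "first", "only" and "open" are said of these compounds alone.

Three compounds share one core and differ only in the group attached on an aromatic carbon para to a large group. Compound 1 `COC(=O)/C=C/c1cccc(N(Cc2ccc(/C=C/c3cccc(F)c3)cc2)C(=O)C(C)C)c1` gives 71 nM in an assay on isolated protein with Bile acid receptor (Homo sapiens) as the target; on this read-out lower numbers stand for an effect already at smaller amounts and higher numbers for an effect only at larger amounts of compound. Compound 2 `COC(=O)/C=C/c1cccc(N(Cc2ccc(/C=C/c3scnc3C)cc2)C(=O)C(C)C)c1` gives 228 nM in this assay, and compound 3 `COC(=O)/C=C/c1cccc(N(Cc2ccc(-c3ccc(SC)cc3)cc2)C(=O)C(C)C)c1` gives 51 nM. Compound 3 has the lowest number of the three, but the step of a 1.4-fold lower number from compound 1 to compound 3 (0.14 log units; within the scatter) lies within the scatter, so the two cannot be told apart, while a 4.5-fold lower number from compound 2 to compound 3 (0.65 log units; beyond the scatter) is a clear step.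

Compound 4 `COC(=O)/C=C/c1cccc(N(Cc2ccc(-c3cccc(Cl)c3)cc2)C(=O)C(C)C)c1` is the next step from compound 3: 3-chlorophenyl in place of 4-(methylsulfanyl)phenyl on an aromatic carbon. The closest guide is the pair of compound 1 and compound 3, where a halogen-bearing phenyl reached through a two-carbon chain and a directly attached methylsulfanylphenyl gave numbers within the scatter of each other. Compound 2 to compound 3 shows that a different ring can shift the number, so some movement is possible. The expected step of a 1.5-fold higher number from compound 3 to compound 4 (0.17 log units; within the scatter) is therefore small, with compound 4 estimated at 75 nM in this assay, within a range from 30 nM to 190 nM.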

Compound 4, half-maximal effective concentration: 77 nM
The estimate for compound 4 lay 1.0-fold (0.01 log units) below the measured number, within the range that was stated.
By their numbers in this assay, from the lowest: compounds 3, 1 and 4 (each within the scatter of the next); then compound 2.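

In this assay, 3-chlorophenyl in place of 4-(methylsulfanyl)phenyl gives a 1.5-fold higher number from compound 3 to compound 4 (0.18 log units; within the scatter) and so cannot be told apart from it, which shows that this position accepts a chlorine-bearing ring as well as a sulfur-bearing one. The comparison with the longer group gives a 1.1-fold higher number from compound 1 to compound 4 (0.04 log units; within the scatter) and likewise leaves 3-chlorophenyl and 2-(3-fluorophenyl)ethenyl indistinguishable, so the two-carbon chain is not needed for a number in this range. Only the thiazole-bearing group stands apart, with a 3.0-fold lower number from compound 2 to compound 4 (0.47 log units; beyond the scatter), making compound 2 the one exception among the four.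

On these data alone, whether an amine or a carboxylic acid on this ring would keep the number in the same range stays open. Nothing measured here explains why these groups give such similar numbers.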